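Aryl for ethyl on the ring nitrogen of compound 3

The compounds below may be only part of what the source reports. "The series", "measured", "known", "first", "only" and "open" are said of these compounds alone.

Of the compounds shown here, three have been measured in a functional assay on MG-63 cells (Homo sapiens) for inhibition, read by CCK-8 assay, with a stated time of 72 h, tested at 1 uM; a higher number here means more inhibition at the concentration tested (going by the name of the read-out), a lower number less inhibition. Compound 1 `COc1ccccc1N1C(=O)C(C)SC1c1cccc(C(=O)NCCCCc2ccccc2)c1` gives 94%. Compound 2 `COc1ccccc1N1C(=O)CSC1c1cc(F)cc(C(=O)O)c1` gives 0%, and compound 3 `CCN1C(=O)CSC1c1cccc(C(=O)NCCCCc2ccccc2)c1` gives 0%, level with compound 2 within the scatter and together the lowest of the three, while compound 1 stands far higher. Compound 4 `COc1ccc(F)cc1N1C(=O)CSC1c1cccc(C(=O)NCCCCc2ccccc2)c1` has not yet been measured. It differs from compound 3 in one place: 5-fluoro-2-methoxyphenyl in place of ethyl on an amide-type nitrogen in a ring. Compound 1, which also bears an aryl group on an amide-type nitrogen in a ring, gives 94%, so a large upward step is expected for compound 4, with a number 70 percentage points higher from compound 3 to compound 4 (beyond the scatter) as the estimate. Compound 4 is estimated at 70%, in a range from 30% to 95%.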

Compound 4, a percentage reported as inhibition, at one concentration (the size of the read-out at that concentration, not a potency): 86%
The estimate for compound 4 lay 16 percentage points below the measured number; the range from low to high includes it.
By their numbers in this assay, from the lowest: compounds 2 and 3 (each within the scatter of the next); then compounds 4 and 1 (each within the scatter of the next).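

In this assay the change of ethyl to 5-fluoro-2-methoxyphenyl on the amide-type nitrogen in a ring gives a number 86 percentage points higher from compound 3 to compound 4 (beyond the scatter) with the rest of the molecule unchanged. Within the data shown here, this is the first single-place comparison, and it shows that the group on this nitrogen alone can decide whether the compound inhibits at the concentration tested. Nothing measured here accounts for the step.

Going by these compounds, whether the fluoro or the methoxy group on the aryl ring is needed stays open. So does whether a plain phenyl, a pyridine ring or a benzyl group on this nitrogen would serve as well.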